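Dropping the methoxy from a pyrazoline anticonvulsant scaffold

This account rests on a few compounds, and the source may have more. Where it says the series, first, only, none or still open, it means among the compounds named here.

The measure used throughout is a functional assay on the whole organism (Hindlimb, strain albino) with Mus musculus as the target, in the maximal electroshock model, with a stated time of 0.5 h; a higher number here means that more compound is needed for the effect, a lower number that less compound is needed. Compound 1, `COc1ccc(C2CC(Nc3nc4ccc(C)cc4s3)=NN2C(C)=O)cc1`, gives 37.3 umol/kg in this assay, which is the lowest of the two numbers recorded. Among the measured compounds shown here, the only other measured compound is compound 2, `COc1ccc(/C=C/C(=O)Nc2nc3ccc(C)cc3s2)cc1`, which in this assay gives 209 umol/kg; its number is higher than that of compound 1 by a margin beyond the usual scatter, but the two structures differ in more than one place, so no single step can be read from the pair.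

Compound 3, `CC(=O)N1N=C(Nc2nc3ccc(C)cc3s2)CC1c1ccccc1`, has not yet been measured. It differs from compound 1 in one place: hydrogen in place of methoxy on an aromatic carbon. For the measured compounds named here, no measured pair shows this change, so the size of its effect is unknown here. The author expects a small step from compound 1 to compound 3, most likely toward a somewhat higher number, and quite possibly within the scatter. The expected step is a 1.5-fold higher number from compound 1 to compound 3 (0.17 log units; within the scatter). Compound 3 is estimated at 55 umol/kg, with a range from 22 umol/kg to 140 umol/kg.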

Compound 3, dose for half-maximal effect: 106 umol/kg
The estimate for compound 3 lay 1.9-fold (0.28 log units) below the measured number, and the stated range covers the measured number.
By their numbers in this assay, from the lowest: compound 1; then compounds 3 and 2 (each within the scatter of the next).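

Among the compounds shown here, replacing the methoxy with hydrogen on this aromatic carbon, para to a large group, is the first single change that can be read in this assay, and it gives a 2.8-fold higher number from compound 1 to compound 3 (0.45 log units; beyond the scatter). The methoxy therefore matters at this position: with the rest of the core of compound 1 unchanged, the change from 4-methoxyphenyl to phenyl means that more compound is needed for the effect. The step is modest but beyond the usual scatter, and nothing available here bears on what lies behind it.

As far as these compounds go, this single step compares only methoxy and hydrogen, so it remains open whether an ethoxy, a methyl, a chlorine or a fluorine on the same carbon would give a number close to that of compound 1, close to that of compound 3, or different from both. From the compounds shown here alone, it also remains open whether the same change would have a step of similar size if the acetyl group of compound 1 were replaced by a propionyl group or a longer acyl chain.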